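Working notes: methyl in place of trifluoromethyl

The compounds below may be only part of what the source reports. "The series", "measured", "known", "first", "only" and "open" are said of these compounds alone.

Measured in an ADME assay on Vero cells (Chlorocebus sabaeus) for cytotoxicity, read by MTT assay; a higher number here means a weaker inhibitor, a lower number a stronger inhibitor:
- compound 1 `C=CCOc1cc(OC)c(C(=O)/C=C/c2ccc(O)cc2)c(OCC=C)c1`: 76400 nM
- compound 2 `C=CCOc1cc(OC)c(C(=O)/C=C/c2ccc(C(F)(F)F)cc2)c(OCC=C)c1`: 7200 nM

Compound 2 stands at 7200 nM, the lower of the two numbers in this assay. Going by the values given here, the only measured step, an 11-fold lower number from compound 1 to compound 2 (1.03 log units; beyond the scatter), is large and beyond the scatter. It brought in trifluoromethyl in place of hydroxy on an aromatic carbon.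

The next compound, compound 3 `C=CCOc1cc(OC)c(C(=O)/C=C/c2ccc(C)cc2)c(OCC=C)c1`, is not yet measured. The change is methyl in place of trifluoromethyl on an aromatic carbon, para to a large group. Among the compounds with values here, no measured step makes this exchange, so an 11-fold lower number from compound 1 to compound 2 (1.03 log units; beyond the scatter) bears on it only indirectly, as a sign that this place can move the number. Removing trifluoromethyl is expected to give a moderate rise, smaller than that step, estimated as a 2.8-fold higher number from compound 2 to compound 3 (0.44 log units; beyond the scatter). Compound 3 is expected at 20000 nM, with an estimated range of 7000 nM to 55000 nM.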

Compound 3, half-maximal inhibitory concentration: 211000 nM
Compound 3: the middle estimate sits 11-fold (1.02 log units) below what was measured; the whole stated range lies below it.
By their numbers in this assay, from the lowest: compound 2; then compound 1; then compound 3.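

The exchange of 4-(trifluoromethyl)phenyl for 4-methylphenyl gives a 29-fold higher number from compound 2 to compound 3 (1.47 log units; beyond the scatter) in this assay, so the low number of compound 2 does not carry over to a small carbon group at this place. Hydroxy and methyl also stay apart, with a 2.8-fold higher number from compound 1 to compound 3 (0.44 log units; beyond the scatter), which makes this place sensitive to the group it carries and leaves trifluoromethyl alone at the low end among these three compounds. No measurement at hand gives a reason for these differences.

The compounds shown do not tell whether the low number belongs to trifluoromethyl alone or would also appear with a chlorine atom, a nitrile or an amine at this place. They also leave open whether a longer chain would move the number further up, as methyl does.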